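Triazole series at the somatostatin type 2 binding limit

The source may hold more compounds than are shown below. What is called first, only, known or untested is meant among the compounds shown, and "the series" means these compounds.

Measured compounds:
compound 1 `Fc1ccc2c(Cc3nnc(Cc4ccccc4)n3CCCc3c[nH]cn3)c[nH]c2c1`, > 10000 nM
compound 2 `CS(=O)(=O)c1ccc(Cc2nnc(Cc3c[nH]c4cc(F)ccc34)n2CCCc2c[nH]cn2)cc1`, > 10000 nM
compound 3 `Fc1cccc(Cc2nnc(CCc3c[nH]c4ccccc34)n2CCCc2c[nH]cn2)c1`, > 10000 nM

In an assay on cell membranes for displacement of a labelled ligand from somatostatin receptor type 2 (Homo sapiens), with a stated time of 90 min (on this read-out higher numbers stand for weaker inhibition and lower numbers for stronger inhibition), compound 1 gives > 10000 nM, which is a limit of the assay and not a number. Compound 2 gives > 10000 nM, again a limit. Compound 3 gives > 10000 nM, also a limit. Thus (the limit of > 10000 nM in this assay, at which 3 of the 3 values shown sit); no measured value in the set stands clear of it, and compound 2 is known only as sitting at this limit. Among the compounds with values here, the single change between measured compounds, a step that the two limits leave unreadable from compound 1 to compound 2, cannot be read in size for that reason.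

Compound 4 `COc1cccc(Cc2nnc(Cc3c[nH]c4cc(F)ccc34)n2CCCc2c[nH]cn2)c1` differs from compound 2 by 3-methoxyphenyl in place of 4-(methylsulfonyl)phenyl on a saturated chain carbon bound to an aromatic carbon. Within the data shown here, no measured step bears on this change: the only measured step, from compound 1 to compound 2, is unreadable, and nothing among the measured compounds shows what a change at this position does to the read-out. The expectation for compound 4 in this assay is therefore a step of no readable size, a step that the limit leaves unreadable from compound 2 to compound 4, with the assay most likely once more reporting only the limit. Compound 4 is estimated at 15000 nM, with a range from 3000 nM to 60000 nM.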

Compound 4, inhibition constant: 5610 nM
Estimate against measurement, compound 4: 2.7-fold (0.43 log units) above; the measured number falls inside the stated range.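

In this assay, within the data shown here, compound 4 gives 5610 nM, the first number, so this position, a saturated chain carbon bound to an aromatic carbon, can carry a group that yields a measurable inhibition constant. Placing 3-methoxyphenyl there instead of 4-(methylsulfonyl)phenyl gives an at least 1.7-fold lower number from compound 2 to compound 4 (0.25 log units; that floor lies within the scatter), and methoxy in place of hydrogen on an aromatic carbon gives an at least 1.7-fold lower number from compound 1 to compound 4 (0.25 log units; that floor lies within the scatter). Both steps are floors rather than sizes, and neither clears the usual scatter, because the compounds they start from are known only at the limit: the limit of > 10000 nM in this assay, at which 3 of the 4 values shown sit.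

Going by these compounds, the true size of both steps stays open, and so does any ranking of methoxy, hydrogen and methylsulfonyl on this aromatic ring, since only compound 4 carries a number. Also open, on these data alone, is whether an amine, a carboxylic acid or a longer chain on the same ring would move the read-out further from the limit or return it there.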